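The source may report more compounds than this note shows. Statements on the series, on what has been measured and on what is new or still open speak of the compounds shown alone.

Three compounds sharing the core of compound 1, `C=CCc1ccc(OCc2cn(-c3ccc(C#N)cc3)nn2)c(O)c1`, have been tested in a functional assay on MCF7 cells (Homo sapiens) for inhibition, read by MTT assay, with a stated time of 72 h, tested at 50 uM; on this read-out lower numbers stand for less inhibition of growth and higher numbers for more inhibition of growth at the one concentration tested. Compound 1 gives 35.6%. Compound 2, `C=CCc1ccc(OCc2cn(-c3ccccc3Cl)nn2)c(O)c1`, gives 34.3%, and compound 3, `C=CCc1ccc(OCc2cn(-c3ccccc3CO)nn2)c(O)c1`, gives 40.4%. Compound 1 stands second highest of these three numbers, yet all three lie within the scatter of one another: a number 1.3 percentage points lower from compound 1 to compound 2 (within the scatter), a number 4.8 percentage points higher from compound 1 to compound 3 (within the scatter), and a number 6.1 percentage points higher from compound 2 to compound 3 (within the scatter). Compound 4, `C=CCc1ccc(OCc2cn(-c3ccc(C(=O)c4ccccc4)cc3)nn2)c(O)c1`, differs from compound 1 by benzoyl in place of cyano on an aromatic carbon. Each measured step likewise exchanges a group on the aryl attached to an aromatic nitrogen, and none moved this assay beyond the scatter. No step beyond the scatter is therefore expected for compound 4 either, a number 2.4 percentage points higher from compound 1 to compound 4 (within the scatter). Compound 4 is estimated at 38%, with a likely range from 24% to 54%.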

Compound 4, percent growth inhibition at one concentration: 35.6%
Estimate against measurement, compound 4: 2.4 percentage points above; the measured number falls inside the stated range.
By their numbers in this assay, from the lowest: compounds 2, 1, 4 and 3 (each within the scatter of the next).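

In this assay, benzoyl in place of cyano gives no change at the digits printed from compound 1 to compound 4 (within the scatter). Benzoyl brings 8 heavy atoms and a six-membered aromatic ring of its own where cyano had 2 heavy atoms, so this position carries a much larger group without a step beyond the scatter. Nothing available explains this flat result.

On these data alone, whether an amine or a carboxylic acid at this position would move this assay beyond the scatter remains open. The single tested concentration also leaves open how these compounds compare at other concentrations.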